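The compounds below may be only part of what the source reports. "The series", "measured", "known", "first", "only" and "open" are said of these compounds alone.

Measured so far:
compound 1 `CCn1c(=O)n(C2OC(CO)[C@@H](O)[C@H]2O)c2nc(N)nc(O)c21`: 82%
compound 2 `C=CCn1c(=S)n(C2OC(COCc3ccccc3)[C@H]3OC(C)(C)O[C@@H]23)c2nc(N)nc(O)c21`: 77%

In a functional assay on the whole organism (B cells) with Mus musculus as the target (on this read-out lower numbers stand for smaller maximal responses and higher numbers for larger maximal responses), compound 1 gives 82%, and compound 2 gives 77%; the two numbers lie within the usual scatter of each other, so neither can be set above the other. Compound 3 `COc1ccc(Cn2c(=O)n(C3OC(CO)[C@@H](O)[C@H]3O)c3nc(N)nc(O)c32)cc1` has not yet been measured. It differs from compound 1 by 4-methoxyphenyl in place of methyl on a saturated chain carbon bound to an aromatic nitrogen. Within the data shown here, no pair of measured compounds shows this change, and the two measured numbers lie close together, so the step from compound 1 to compound 3 is expected to be a number 4 percentage points lower from compound 1 to compound 3 (within the scatter), not beyond the scatter. Compound 3 is therefore estimated at 78%, between 60% and 95%.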

Compound 3, largest response reached (reported as maximal response), in percent of the reference or control that the assay uses: 44%
The estimate for compound 3 lay 34 percentage points above the measured number; measured number below the stated range.
By their numbers in this assay, from the lowest: compound 3; then compounds 2 and 1 (each within the scatter of the next).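

The change of ethyl to 4-methoxybenzyl on the shared core gives a number 38 percentage points lower from compound 1 to compound 3 (beyond the scatter) in this assay. Among these compounds, this is the first step read at this position, and it shows that the maximal response depends on what the saturated chain carbon bound to the aromatic nitrogen carries. Nothing at hand speaks to why the response falls.

The compounds shown leave open whether a plain benzyl or a longer chain such as butyl would lower the response as well. They also leave open whether the step goes with the ring or with its methoxy group.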